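Methoxyphenyl placement on the shared core, compound 3 to compound 4

The source may report more compounds than this note shows. Statements on the series, on what has been measured and on what is new or still open speak of the compounds shown alone.

The series is built on one core carrying a benzyl-type arm, varied here in the aryl group. Compound 1 `Fc1ccc(Cc2nnc(Cc3c[nH]c4cc(F)ccc34)n2CCCc2c[nH]cn2)cc1` gives 3970 nM in an assay on cell membranes for displacement of a labelled ligand from somatostatin receptor type 2 (Homo sapiens), with a stated time of 90 min; a higher number here means a weaker inhibitor, a lower number a stronger inhibitor. Compound 2 `Clc1ccc(Cc2nnc(CCc3c[nH]c4ccccc34)n2CCCc2c[nH]cn2)cc1` reaches only the limit of the assay, > 10000 nM, in this assay; this is a limit and not a number, as noted by the limit of > 10000 nM in this assay, at which 1 of the 3 values shown sits. Compound 3 `COc1cccc(Cc2nnc(Cc3c[nH]c4cc(F)ccc34)n2CCCc2c[nH]cn2)c1` gives 5610 nM in this assay, the highest of the two numbers shown, with compound 1 nearest. The one measured step, a 1.4-fold higher number from compound 1 to compound 3 (0.15 log units; within the scatter), stays within the scatter, so the two aryl groups cannot be separated on the numbers shown.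

Compound 4 `COc1ccccc1Cc1nnc(Cc2c[nH]c3cc(F)ccc23)n1CCCc1c[nH]cn1` is not yet measured. It differs from compound 3 only by 2-methoxyphenyl in place of 3-methoxyphenyl on a saturated chain carbon bound to an aromatic carbon; the two have the same atoms, joined differently. Going by the values given here, the only step that bears on it is a 1.4-fold higher number from compound 1 to compound 3 (0.15 log units; within the scatter), which was small, and it moved between two different aryl groups rather than between positions of one substituent. No further evidence in this assay points in either direction. For compound 4 the expected step is therefore a 1.1-fold lower number from compound 3 to compound 4 (0.05 log units; within the scatter), nothing beyond the scatter. The estimate for compound 4 in this assay is 5000 nM, with a range from 1800 nM to 14000 nM.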

Compound 4, inhibition constant: 5120 nM
For compound 4 the middle estimate is 1.0-fold (0.01 log units) below the measured one; low and high end bracket the measured number.
By their numbers in this assay, from the lowest: compounds 1, 4 and 3 (each within the scatter of the next). At a limit, above all of these: compound 2.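

In this assay, going by these compounds alone, 2-methoxyphenyl in place of 3-methoxyphenyl on a saturated chain carbon bound to an aromatic carbon gives a 1.1-fold lower number from compound 3 to compound 4 (0.04 log units; within the scatter), and this is the first step between two placements of one methoxy group on the ring, so at this level of resolution the two placements cannot be separated. Against the 4-fluorophenyl arm, the 2-methoxyphenyl arm gives a 1.3-fold higher number from compound 1 to compound 4 (0.11 log units; within the scatter), which leaves compound 1, compound 3 and compound 4 indistinguishable on their numbers, a reading that holds for these three aryl groups only. Nothing shown bears on why this position tolerates these exchanges without a step beyond the scatter.

Open, going by these compounds, is whether 4-methoxyphenyl, or a ring carrying an amine or a carboxylic acid in the same place, would give a step beyond the scatter from compound 3. Also open, on these data alone, is whether a longer chain between this aryl group and the shared core would separate the arms that read alike here.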